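The source may hold more compounds than are shown below. What is called first, only, known or untested is meant among the compounds shown, and "the series" means these compounds.

Three compounds built on one shared core were tested in an ADME assay on BJ cells (Homo sapiens) for cytotoxicity, read by MTT assay, with a stated time of 72 h; on this read-out higher numbers stand for weaker inhibition and lower numbers for stronger inhibition. Compound 1 has the structure `Oc1ccccc1CNc1ncnc2c1ncn2C1CCCCO1`. In this assay compound 1 gives > 100000 nM, which is a limit of the assay and not a number. Compound 2, with the structure `COc1ccc(CNc2ncnc3c2ncn3C2CCCCO2)cc1`, differs from compound 1 by 4-methoxyphenyl in place of 2-hydroxyphenyl on a saturated chain carbon bound to a nitrogen on an aromatic ring. In this assay compound 2 gives > 100000 nM, again a limit. Compound 3, with the structure `COc1cccc(CNc2ncnc3c2ncn3C2CCCCO2)c1O`, differs from compound 1 by methoxy in place of hydrogen on an aromatic carbon. In this assay compound 3 gives > 100000 nM, also a limit. The step that the two limits leave unreadable from compound 1 to compound 2 cannot be read because of the limit of > 100000 nM in this assay, at which 3 of the 3 values shown sit. The same is true of a step that the two limits leave unreadable from compound 1 to compound 3.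

Compound 4, with the structure `COc1ccc(CNc2ncnc3c2ncn3C2CCCCO2)c(OC)c1`, has not yet been measured; it differs from compound 2 by methoxy in place of hydrogen on an aromatic carbon. This is the same kind of change as from compound 1 to compound 3, but not the same change: there the entering methoxy sat ortho to a hydroxy group and meta to a large group, whereas here it sits ortho to a large group and meta to a methoxy group. Compound 4 is expected to show a step that the limit leaves unreadable from compound 2 to compound 4 in this assay. That expectation rests on compound 3, which gives > 100000 nM after the same kind of change. In this assay compound 4 is therefore estimated at 150000 nM, with a likely range from 50000 nM to 500000 nM.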

Compound 4, half-maximal inhibitory concentration: > 25000 nM
Compound 4 was reported as a limit; the forecaster's own chance of this, stated with the estimate: 85%; the middle value is on the limit's open side.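

No size can be read for the step from compound 2 to compound 4, because both results are limits and not numbers; compound 2 sits at one limit: the limit of > 100000 nM in this assay, at which 3 of the 4 values shown sit. Compound 4 sits at another: the limit of > 25000 nM in this assay, at which 1 of the 4 values shown sits. The compounds shown leave open at what concentration, if any, each of the four would reach half-maximal inhibition in this assay.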